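Chloroacetamide to crotonamide on the benzylic anilide

A few compounds are considered here, and "the series" means these few. Any claim that something is new, unique, unknown or untested is made for them only; others in the source may bear on it.

Working notes on the series. Compound 1 `O=C(CCl)Nc1ccc(Cn2nc(-c3ccc(Oc4ccccc4)cc3)cc2CO)cc1` and compound 2 `CCOC(=O)c1cc(-c2ccc(Oc3ccccc3)cc2)nn1Cc1cccc(NC(=O)CCl)c1` share the diaryl ether pyrazole core and both carry a chloroacetamide on the benzyl ring. In a functional assay on JeKo-1 cells (Homo sapiens) for inhibition, read by luminescence and CellTiter-Glo, with a stated time of 72 h (a higher number here means a weaker inhibitor, a lower number a stronger inhibitor), compound 1 gives 400 nM and compound 2 gives 400 nM; compound 2 stands level with compound 1 at the digits shown, the two values lying within the scatter of each other, so nothing can be said about an order between them.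

Compound 3 `C/C=C/C(=O)Nc1ccc(Cn2nc(-c3ccc(Oc4ccccc4)cc3)cc2C(=O)OCC)cc1` is the next point. Against compound 2 the change is 4-(((prop-1-en-1-yl)carbonyl)amino)phenyl in place of 3-(((chloromethyl)carbonyl)amino)phenyl on a saturated chain carbon bound to an aromatic nitrogen. Within the data shown here, no step between measured compounds is available that isolates this change, so the size of the step is open. On the numbers at hand, the expectation is a moderate move toward weaker inhibition in this assay, larger than the scatter but not by much, and the estimated step of a 3.8-fold higher number from compound 2 to compound 3 (0.57 log units; beyond the scatter) reflects that. For compound 3 the estimate in this assay is 1500 nM, with a range from 400 nM to 6000 nM.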

Compound 3, half-maximal inhibitory concentration: 52500 nM
Compound 3: middle estimate off by 35-fold (1.54 log units), on the low side; measured number above the stated range.
By their numbers in this assay, from the lowest: compounds 1 and 2 (each within the scatter of the next); then compound 3.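

In this assay, the group on a saturated chain carbon bound to an aromatic nitrogen proves far from indifferent: 4-(((prop-1-en-1-yl)carbonyl)amino)phenyl in place of 3-(((chloromethyl)carbonyl)amino)phenyl gives a 130-fold higher number from compound 2 to compound 3 (2.12 log units; beyond the scatter), a large step well beyond the scatter, of which the level values of compound 1 and compound 2 gave no hint. The step carries two differences at once, since the two group names differ both in the acyl part and in the ring number, so it belongs to the combined change and cannot be assigned to either part alone. No measurement is available that bears on the reason for this loss.

On these data alone, the split between the two parts stays open: 3-(((prop-1-en-1-yl)carbonyl)amino)phenyl or 4-(((chloromethyl)carbonyl)amino)phenyl on the core of compound 2 would separate them. Also open, as far as these compounds go, is whether the weak value of compound 3 is specific to the prop-1-en-1-yl group, or would hold for a plain ethenyl group or for a chain ending in a dimethylamino group.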